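A few compounds are considered here, and "the series" means these few. Any claim that something is new, unique, unknown or untested is made for them only; others in the source may bear on it.

Compound 1 `CN1C[C@H]2C=C(c3cccnc3)C[C@H](C2)C1`: 11%
Compound 2 `C1=C(c2cccnc2)C[C@@H]2CNC[C@H]1C2`: 131%

For the measured compounds named here, of the two numbers in an in vitro functional assay on SH-EP1 cells for agonist activity at Neuronal acetylcholine receptor; alpha4/beta2 (Homo sapiens), read by FLIPR and calcium flux (on this read-out lower numbers stand for smaller maximal responses and higher numbers for larger maximal responses), compound 2 stands highest; its only neighbour, compound 1, lies far lower, a gap beyond the scatter. Compound 3 `CN1C[C@@H]2C=C(c3cccnc3)C[C@@H](C2)C1` is not yet measured. Against compound 2 it carries methyl in place of hydrogen on an amine nitrogen in a ring. Going by the values given here, no measured pair shows this change on its own, so its size cannot be read from the data; still, compound 1 also carries the methyl and gives only 11%, which points toward a loss of maximal response. In this assay the expected step is a number 91 percentage points lower from compound 2 to compound 3 (beyond the scatter). Compound 3 is estimated at 40%, with a range of 8% to 110%.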

Compound 3, largest response reached (reported as percent of maximum), in percent of the reference or control that the assay uses: 17%
For compound 3 the middle estimate is 23 percentage points above the measured one; the measured number falls inside the stated range.
By their numbers in this assay, from the lowest: compounds 1 and 3 (each within the scatter of the next); then compound 2.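

In this assay, for the compounds shown here, methyl in place of hydrogen on an amine nitrogen in a ring now has a measured size: a number 114 percentage points lower from compound 2 to compound 3 (beyond the scatter) is a large step and the first direct reading of this change. The mirror-image methyl pair gives a number 6 percentage points higher from compound 1 to compound 3 (within the scatter) so that, with the methyl present, configuration shows no separation on this read-out. This comparison isolates configuration alone: the fact that compounds 1 and 3 differ only in the configuration as drawn

From the compounds shown here alone, whether configuration matters with hydrogen on that nitrogen stays open, since the mirror image of compound 2 is absent here. Also open, going by these compounds, is whether an ethyl group or a longer chain on that nitrogen would track the methyl result.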